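Notes on the amine substituent: compound 3 to compound 4

A few compounds are considered here, and "the series" means these few. Any claim that something is new, unique, unknown or untested is made for them only; others in the source may bear on it.

Measured so far in an assay on isolated protein for activation of cGMP-dependent protein kinase 1 (Homo sapiens), read by ADP-Glo, with stated times of 120 min and 40 min; on this read-out lower numbers stand for an effect already at smaller amounts and higher numbers for an effect only at larger amounts of compound:
- compound 1 `Clc1cc(Cl)cc(CO[C@H]2CCCN(Cc3cccnc3)[C@H]2c2ccccc2)c1`: 112000 nM
- compound 2 `CN1CCC[C@H](OCc2cc(Cl)cc(Cl)c2)[C@@H]1c1ccccc1`: only the assay limit, > 200000 nM
- compound 3 `O=C(O)c1ccc(CN2CCC[C@H](OCc3cc(Cl)cc(Cl)c3)[C@@H]2c2ccccc2)cc1`: 76000 nM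

Compound 3 holds the lowest of the two numbers in this assay; compound 1 sits nearby, and a 1.5-fold lower number from compound 1 to compound 3 (0.17 log units; within the scatter) stays within the scatter. Against compound 2 the gap an at least 2.6-fold lower number from compound 2 to compound 3 (0.42 log units; beyond the scatter) is at least modest, though that comparison rests on (the limit of > 200000 nM in this assay, at which 1 of the 3 values shown sits).

Compound 4 `COc1ccc(C(=O)O)cc1CN1CCC[C@H](OCc2cc(Cl)cc(Cl)c2)[C@@H]1c1ccccc1` differs from compound 3 by 5-carboxy-2-methoxyphenyl in place of 4-carboxyphenyl on a saturated chain carbon bound to an amine nitrogen in a ring. For the measured compounds named here, no measured step swaps one aryl group for another of this kind; the steps known so far only exchange pyridin-3-yl, hydrogen and 4-carboxyphenyl at that position, and the two numbered ones lie within or barely beyond the scatter. For compound 4 the expected step of a 1.1-fold higher number from compound 3 to compound 4 (0.02 log units; within the scatter) is therefore none beyond the scatter. Compound 4 is thus estimated at 80000 nM in this assay, within 30000 nM to 200000 nM.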

Compound 4, half-maximal effective concentration: 123000 nM
Estimate against measurement, compound 4: 1.5-fold (0.19 log units) below; low and high end bracket the measured number.
By their numbers in this assay, from the lowest: compounds 3, 1 and 4 (each within the scatter of the next). At a limit, above all of these: compound 2.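

In this assay, for the compounds shown here, the first exchange of one aryl group for another at this position gives a 1.6-fold higher number from compound 3 to compound 4 (0.21 log units; within the scatter), and against the pyridin-3-yl of compound 1 the step is a 1.1-fold higher number from compound 1 to compound 4 (0.04 log units; within the scatter). The three aryl groups of compounds 1, 3 and 4 thus stay within the scatter of one another, despite the added methoxy group. Compound 2 stands at an assay limit, and the step to the larger group reads an at least 1.6-fold lower number from compound 2 to compound 4 (0.21 log units; that floor lies within the scatter), a weaker separation from hydrogen than compound 3 gave: the limit of > 200000 nM in this assay, at which 1 of the 4 values shown sits.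

Still open, going by these compounds, is whether the carboxylic acid matters here at all. Also open, on these data alone, is what a primary amide, a tetrazole or a longer chain on the amine nitrogen in the ring would do at this position.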